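This account rests on a few compounds, and the source may have more. Where it says the series, first, only, none or still open, it means among the compounds named here.

Measured compounds in a functional assay on SK-BR-3 cells (Homo sapiens) for inhibition, read by CellTiter-Glo, with a stated time of 72 h; on this read-out lower numbers stand for stronger inhibition and higher numbers for weaker inhibition:
Compound 1, `CC(C)c1nn(-c2ccc(C(N)=O)c(N[C@H]3CC[C@H](O)CC3)c2)c2nccc(-n3cnc(-c4ccncc4)c3)c12`: 165 nM.
Compound 2, `COc1ccc(-c2cn(-c3ccnc4c3c(C(C)C)nn4-c3ccc(C(N)=O)c(N[C@H]4CC[C@H](O)CC4)c3)cn2)cc1`: 256 nM.
Compound 3, `CC(C)c1nn(-c2ccc(C(N)=O)c(N[C@H]3CC[C@H](O)CC3)c2)c2nccc(-c3ccccc3)c12`: > 10000 nM, a limit of the assay rather than a number.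

Compound 3 therefore sits at the weak end of the three; what is known of it in this assay is only a limit, (the limit of > 10000 nM in this assay, at which 1 of the 3 values shown sits). Compound 4, `CC(C)c1nn(-c2ccc(C(N)=O)c(N[C@H]3CC[C@H](O)CC3)c2)c2nccc(-c3ccsc3)c12`, differs from compound 3 in one place: thiophen-3-yl in place of phenyl on an aromatic carbon. Two measured steps exist. The step of an at least 60-fold higher number from compound 1 to compound 3 (1.78 log units; beyond the scatter) was large, beyond the scatter, and shows that exchanging the larger group of compound 1 for phenyl at this position moves the value out to the limit. The step of a 1.6-fold higher number from compound 1 to compound 2 (0.19 log units; within the scatter) stayed within the scatter. Neither step exchanges phenyl for thiophen-3-yl, so there is no direct guide; both rings are single aromatic rings at the same place. Compound 4 is expected to stay close to compound 3, with an expected step that the limit leaves unreadable from compound 3 to compound 4 that is not beyond the scatter. The estimate for compound 4 is therefore 15000 nM, with a range from 3000 nM to 60000 nM, and most likely again only a limit.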

Compound 4, half-maximal inhibitory concentration: > 10000 nM
Compound 4 was reported as a limit; the forecaster's own chance of this, stated with the estimate: 70%; the middle value is on the limit's open side.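

Putting thiophen-3-yl in place of the 4-(pyridin-4-yl)-1H-imidazol-1-yl group gives an at least 60-fold higher number from compound 1 to compound 4 (1.78 log units; beyond the scatter), so the large loss seen with phenyl at this position is not particular to phenyl. It now holds for a five-membered aromatic ring with a sulfur atom as well as for a six-membered ring of carbon only. The step from phenyl to thiophen-3-yl itself cannot be read, because both values are limits of the assay: the limit of > 10000 nM in this assay, at which 2 of the 4 values shown sit.

Still open, from the compounds shown here alone, is whether an unsubstituted imidazol-1-yl group, without the pyridin-4-yl or 4-methoxyphenyl group on it, would bring a value near that of compound 1 in this assay. Also open, going by these compounds, is what a simple amine or a carboxylic acid would do on this aromatic carbon.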